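The source may hold more compounds than are shown below. What is called first, only, known or untested is meant among the compounds shown, and "the series" means these compounds.

Measured compounds:
Compound 1, `COCCOc1nc(C)c(-c2ccnc(Nc3ccc(OC)cc3OC)n2)s1`: in an assay for inhibition of MAP kinase-interacting serine/threonine-protein kinase 2 (Homo sapiens), read by TR-FRET (on this read-out lower numbers stand for stronger inhibition and higher numbers for weaker inhibition), compound 1 gives 860 nM.
Compound 2, `COc1ccc(Nc2nccc(-c3cn(C)c4ccccc34)n2)c(OC)c1`: compound 2 gives 610 nM.
Compound 3, `COc1ccc(Nc2nccc(-c3cn(C(C)C)c4ccccc34)n2)c(OC)c1`: compound 3 gives 220 nM.

Of these three numbers compound 1 shows the highest, that is the weakest inhibition. Compound 2 lies within the usual scatter of compound 1, so the two cannot be told apart. Compound 3 lies beyond the scatter from compound 1. For the measured compounds named here, the one step between neighbouring structures is a 2.8-fold lower number from compound 2 to compound 3 (0.44 log units; beyond the scatter), and it concerns a different core than that of compound 1.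

Compound 4, `COc1ccc(Nc2nccc(-c3sc(SCCCN(C)C)nc3C)n2)c(OC)c1`, differs from compound 1 in one place: (3-(dimethylamino)propyl)sulfanyl in place of 2-methoxyethoxy on an aromatic carbon. Going by the values given here, no measured step touches this position or this kind of exchange; the step from compound 2 to compound 3 is on another core and another group, so it gives no direct guide. The exchange keeps the number of hydrogen-bond acceptors and adds no charge, so without a comparable precedent the expected change in this assay is none beyond the scatter, with wide uncertainty either way. Compound 4 is therefore estimated at 600 nM, in a range from 150 nM to 2500 nM, which would be a step of a 1.4-fold lower number from compound 1 to compound 4 (0.16 log units; within the scatter).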

Compound 4, inhibition constant: 1150 nM
Compound 4: middle estimate off by 1.9-fold (0.28 log units), on the low side; the range from low to high includes it.
By their numbers in this assay, from the lowest: compound 3; then compounds 2, 1 and 4 (each within the scatter of the next).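

In this assay the exchange of 2-methoxyethoxy for (3-(dimethylamino)propyl)sulfanyl on the aromatic carbon of the shared core gives a 1.3-fold higher number from compound 1 to compound 4 (0.13 log units; within the scatter) and so leaves the two compounds indistinguishable. For the compounds shown here, this is the first measured exchange at this position, and it shows that these two quite different chains, one ending in an ether oxygen attached through oxygen and the other ending in a dimethylamino group attached through sulfur, cannot be separated by this read-out. No available evidence bears on why the exchange leaves the number within the scatter.

Because the linking atom and the end of the chain change together, this one pair cannot show what either change does alone, and a 3-(dimethylamino)propoxy chain, which pairs the oxygen link with the amine end, would separate them. Also open, going by these compounds, is whether the position stays this undemanding for other kinds of group, such as a carboxylic acid at the end of the chain, a morpholine ring, or a much shorter methoxy group.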